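The compounds below may be only part of what the source reports. "The series", "measured", "known", "first", "only" and "open" are said of these compounds alone.

compound 1 `CCOC(=O)c1c(C)nc(-c2cccc(C#N)c2)n1OCCCO` gives 11400 nM
compound 2 `CCOC(=O)c1c(C)nc(-c2cccc(C#N)c2)n1OCc1ccccc1Cl` gives 8710 nM

Among the measured compounds shown here, both numbers come from a functional assay on a cell-free system (plasma, Oryctolagus cuniculus) for inhibition, with stated times of 5 min, 1 min and 6 min (a higher number here means a weaker inhibitor, a lower number a stronger inhibitor), and lie within the scatter of each other, so compound 2 does not stand apart from compound 1 on the numbers so far. Next in line is compound 3 `CCOC(=O)c1c(C)nc(-c2cccc(C#N)c2)n1OCc1ccc(OC)cc1` which has not yet been measured. The difference is 4-methoxyphenyl in place of 2-chlorophenyl on a saturated chain carbon bound to an oxygen on an aromatic ring and, in words, 4-methoxyphenyl in place of 2-chlorophenyl on a saturated chain carbon bound to an oxygen on an aromatic ring. For the measured compounds named here, one measured step bears on this change: a 1.3-fold lower number from compound 1 to compound 2 (0.12 log units; within the scatter) at that same place, and it stays within the scatter. Going by the values given here, that step replaces a different group, and no measured pair compares two substituted phenyl groups, so the data give no direction. No step beyond the scatter is expected in this assay and the estimated step is a 1.0-fold higher number from compound 2 to compound 3 (0.01 log units; within the scatter) with neither direction favoured. For compound 3 the estimate is 9000 nM with an expected range from 4000 nM to 20000 nM on present evidence.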

Compound 3, half-maximal inhibitory concentration: 6830 nM
Compound 3: middle estimate off by 1.3-fold (0.12 log units), on the high side; the measured number falls inside the stated range.
By their numbers in this assay, from the lowest: compounds 3, 2 and 1 (each within the scatter of the next).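

In this assay, among the compounds shown here, exchanging 2-chlorophenyl for 4-methoxyphenyl on a saturated chain carbon bound to an oxygen on an aromatic ring gives a 1.3-fold lower number from compound 2 to compound 3 (0.11 log units; within the scatter), the first measured comparison of two substituted phenyl groups at this place. Exchanging 2-hydroxyethyl for 4-methoxyphenyl at the same place gives a 1.7-fold lower number from compound 1 to compound 3 (0.22 log units; within the scatter), so with all three pairs now within the scatter, neither the 2-hydroxyethyl group, the 2-chlorophenyl group nor the 4-methoxyphenyl group stands apart from the others at this position. No accompanying measurement bears on these results.

The compounds shown leave open whether this position would separate from these three numbers with a group of another kind, such as an amine, a carboxylic acid, a longer chain or a phenyl ring without any substituent. They also leave open how the rest of the shared core contributes, since the ethyl ester, the methyl group and the nitrile-bearing phenyl ring stay the same in all three compounds, and a carboxylic acid in place of that ester remains one untested comparison in this set.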